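Swapping a Hydroxy for a Methoxy at the Assay Limit

The compounds below may be only part of what the source reports. "The series", "measured", "known", "first", "only" and "open" are said of these compounds alone.

Of the compounds shown here, three have been tested so far in a functional assay on NCI-H1792 cells (Homo sapiens) for cytotoxicity, read by resazurin assay, with a stated time of 72 h (a lower number here means a stronger inhibitor, a higher number a weaker inhibitor), and only one returned an actual number. Compound 1 `COc1cc(/C=C/C(=O)OCCCCCCO[N+](=O)[O-])ccc1O` gives 48700 nM as a true measured value. Compound 2 `O=C(/C=C/c1ccc(OCCCCO[N+](=O)[O-])c(O)c1)OCCCCO[N+](=O)[O-]` gives > 50000 nM as a reading, which is a limit and not a number. Compound 3 `COc1cc(/C=C/C(=O)OCCCO[N+](=O)[O-])ccc1OCCCO[N+](=O)[O-]` gives > 50000 nM as a reading, which is also a limit. Compound 2 therefore has no exact position on the scale, and the results are framed by the limit of > 50000 nM in this assay, at which 2 of the 3 values shown sit, as their common boundary.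

The next molecule, compound 4 `COc1cc(/C=C/C(=O)OCCCCO[N+](=O)[O-])ccc1OCCCCO[N+](=O)[O-]`, differs from compound 2 in one place (see methyl in place of hydrogen on an oxygen on an aromatic ring for the count). Methyl takes the place of hydrogen on an oxygen on an aromatic ring, turning hydroxy into methoxy. Within the data shown here, no measured pair shows this change directly, so any forecast is uncertain. The expectation leans on compound 3, whose reading of > 50000 nM is another limit. No clear move in either direction is expected, and the estimated step that the limit leaves unreadable from compound 2 to compound 4 stays within the usual scatter of repeat measurements. For compound 4 the expected value is 60000 nM with an estimated range of 30000 nM to 120000 nM and a good chance of only a limit.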

Compound 4, half-maximal inhibitory concentration: > 50000 nM
Compound 4: a limit, no number; the forecaster's own chance of this, stated with the estimate: 70%; the middle value is on the limit's open side.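

Among these compounds, compound 2 and compound 4 both give only a limit and not an actual number, so no step between them can be read: the limit of > 50000 nM in this assay, at which 3 of the 4 values shown sit. The compounds shown leave open whether turning hydroxy into methoxy changes the cytotoxicity at all, or whether any effect lies hidden beyond the limit.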